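Moving a Methoxy Group on a Low-Nanomolar Inhibitor

The source may report more compounds than this note shows. Statements on the series, on what has been measured and on what is new or still open speak of the compounds shown alone.

In a functional assay on THP-1 cells (Homo sapiens) (a higher number here means a weaker inhibitor, a lower number a stronger inhibitor), compound 1 (`CC[C@H]1c2c(cc(F)c(F)c2O)[C@H](Nc2cccc3[nH]c(=O)ccc23)[C@@](O)(C(F)(F)F)C1OC`) gives 6.31 nM as its value, while compound 2 (`CCSC[C@@](O)([C@@H](Nc1cccc2nc(C)ccc12)c1cccc(F)c1OC)C(F)(F)F`) gives 2 nM as its value. Compound 2 therefore holds the lower of the two numbers, which makes it the stronger inhibitor, and the gap lies beyond the usual scatter. These two compounds differ in more than one place, so their gap cannot be pinned on any single change. Compound 3 (`CCSC[C@@](O)([C@@H](Nc1cccc2nc(C)ccc12)c1ccc(OC)c(F)c1)C(F)(F)F`) has the same atoms as compound 2, joined differently: 3-fluoro-4-methoxyphenyl in place of 3-fluoro-2-methoxyphenyl on a saturated chain carbon bound to a nitrogen on an aromatic ring and a saturated chain carbon. For the measured compounds named here, no measured pair shows such a swap, so what follows is a judgment with wide uncertainty. The estimated change (a 10-fold higher number from compound 2 to compound 3 (1.00 log units; beyond the scatter)) is expected to point toward a weaker inhibitor, beyond the scatter. For compound 3 the expected value is 20 nM in this assay, with an estimated range (4 nM to 100 nM).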

Compound 3, half-maximal inhibitory concentration: 5.01 nM
Compound 3: middle estimate off by 4.0-fold (0.60 log units), on the high side; the measured number falls inside the stated range.
By their numbers in this assay, from the lowest: compound 2; then compounds 3 and 1 (each within the scatter of the next).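

For the compounds shown here, this is the first pair that differs in one place, so a change in the number can be tied to a single structural change: in this assay, 3-fluoro-4-methoxyphenyl in place of 3-fluoro-2-methoxyphenyl gives a 2.5-fold higher number from compound 2 to compound 3 (0.40 log units; beyond the scatter) on otherwise identical molecules. The two rings carry the same atoms, so how those atoms are arranged at this position affects the result, although the step is modest and compound 3 still gives 5.01 nM in this assay. No measurement available here explains the step.

The compounds shown leave open whether an ethoxy group or a hydroxyl group in place of the methoxy group would give a similar number. They also leave open whether the same swap would produce a similar step on a different core, such as that of compound 1.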